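Changing the Pendant Phenyl on a Shared Core

The source may hold more compounds than are shown below. What is called first, only, known or untested is meant among the compounds shown, and "the series" means these compounds.

Two compounds of this set share one core and differ only in the aryl group on one aromatic carbon. Compound 1 `CCc1ccc(-c2cn3ccnc3c(-c3ccc4ncn(Cc5ccccc5)c4c3)n2)cc1` carries a 4-ethylphenyl there, and in a functional assay on UACC-62 cells (Homo sapiens) for inhibition, read by sulforhodamine B assay, with a stated time of 48 h, tested at 10 uM (a lower number here means less inhibition, a higher number more inhibition at the concentration tested (going by the name of the read-out)), compound 1 gives 24.9%. Compound 2 `Cc1cccc(-c2cn3ccnc3c(-c3ccc4ncn(Cc5ccccc5)c4c3)n2)c1` carries a 3-methylphenyl instead, and in this assay compound 2 gives 2.46%. Within the data shown here, the single step between them, a number 22.4 percentage points lower from compound 1 to compound 2 (beyond the scatter), is the only one available, and it places compound 2 at the bottom of the two numbers, with compound 1 above it by a margin beyond the scatter.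

Compound 3 `O=Cc1ccc(-c2cn3ccnc3c(-c3ccc4ncn(Cc5ccccc5)c4c3)n2)cc1` is the next member: 4-formylphenyl in place of 3-methylphenyl on an aromatic carbon. Among the measured compounds shown here, the only step that bears on this change is the one from compound 1 to compound 2, which showed that swapping the aryl group at this carbon can move the read-out modestly, and that the 4-substituted phenyl of compound 1 sat higher. For the measured compounds named here, since compound 3 again carries a group in the 4-position, a modest rise in this assay is expected, though the formyl group has no precedent here. The expected step is a number 12.5 percentage points higher from compound 2 to compound 3 (beyond the scatter), and compound 3 is estimated at 15%, between 0% and 35%.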

Compound 3, a percentage reported as inhibition, at one concentration (the size of the read-out at that concentration, not a potency): 37.1%
Beside the measured number, compound 3's estimate is 22.1 percentage points below it, outside the stated range (above it).
By their numbers in this assay, from the lowest: compound 2; then compound 1; then compound 3.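

Replacing the 3-methylphenyl with a 4-formylphenyl gives a number 34.6 percentage points higher from compound 2 to compound 3 (beyond the scatter) in this assay, so this aromatic carbon can carry an aryl group that moves the read-out by a large step, and compound 3 stands highest of the three compounds. Formyl in place of ethyl on the phenyl gives a number 12.2 percentage points higher from compound 1 to compound 3 (beyond the scatter), which shows that the read-out also changes when only the group on the phenyl differs, a comparison the first pair could not offer, as its two aryl groups differ in both the group and where it sits. Nothing available accounts for this order of the three compounds.

The compounds shown do not separate the effect of where a group sits on the phenyl from the effect of which group it is, as none of them carries the same group in both places, so a 4-methylphenyl or a 3-formylphenyl would be the direct test. From the compounds shown here alone, how a phenyl bearing an amine, a carboxylic acid or a longer chain would read in this assay also stays open.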